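A few compounds are considered here, and "the series" means these few. Any claim that something is new, unique, unknown or untested is made for them only; others in the source may bear on it.

In an assay on nucleic acid for inhibition of Nucleic Acid, read by fluorescence, tested at 100 uM (on this read-out lower numbers stand for less inhibition and higher numbers for more inhibition at the one concentration tested (going by the name of the read-out)), compound 3 `CN(Cc1cn(CC(O)COC(=O)NCc2ccccc2)nn1)CC1CCCCC1` gives 32%. Compound 1 `CN(Cc1cn(CC(O)COC(=O)c2ccccc2)nn1)CC1CCCCC1` keeps the same core and differs only by phenyl in place of benzylamino on a carbonyl carbon; in this assay compound 1 gives 6%, and the step is a number 26 percentage points lower from compound 3 to compound 1 (beyond the scatter). Compound 2 `O=C(NCc1ccccc1)OCC(O)Cn1cc(CN2CCN(c3ccccc3)CC2)nn1` carries a different core, and the difference between the two cores is not broken down here; in this assay compound 2 gives 32%, which stands level with compound 3 within the scatter, while compound 1 lies lower than both.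

Compound 4 `O=C(OCC(O)Cn1cc(CN2CCN(c3ccccc3)CC2)nn1)c1ccccc1` is not yet measured. It differs from compound 2 by phenyl in place of benzylamino on a carbonyl carbon, the same change that separates compound 3 from compound 1, made at the same place. Among the compounds with values here, on the strength of that single measured step, compound 4 is expected to fall below compound 2 by about a number 24 percentage points lower from compound 2 to compound 4 (beyond the scatter), because the step of a number 26 percentage points lower from compound 3 to compound 1 (beyond the scatter) is the only guide to this change. Within the data shown here, the expected value for compound 4 is 8%, with a range from -5% to 24%, since only one example supports the estimate.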

Compound 4, a percentage reported as inhibition, at one concentration (the size of the read-out at that concentration, not a potency): 11%
Compound 4: the middle estimate sits 3 percentage points below what was measured, and the stated range covers the measured number.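

In this assay, replacing benzylamino with phenyl on a carbonyl carbon gives a number 21 percentage points lower from compound 2 to compound 4 (beyond the scatter) on the core of compound 2, so the drop seen on the core of compound 3 appears again. Set side by side, the two cases show a change that carries from one core to the other with much the same size: the same change on two cores in this assay, a number 26 percentage points lower (beyond the scatter) from compound 3 to compound 1 and a number 21 percentage points lower (beyond the scatter) from compound 2 to compound 4, 5 percentage points apart, within the scatter of two such steps. This supports transfer between these two cores at the one concentration tested, but it does not show that the change would behave alike on any other core, and the two pairs do not tell which part of the benzylamino group accounts for the difference.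

The compounds shown leave open how a longer chain such as phenethylamino, or a plain amine such as methylamino, would read on the same carbonyl carbon. They also leave open whether a carboxylic acid on the phenyl ring would alter the step, and how these compounds would rank across a range of concentrations.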